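A few compounds are considered here, and "the series" means these few. Any claim that something is new, unique, unknown or untested is made for them only; others in the source may bear on it.

Compound 3 `CC(C)Cc1ccc(C(C)c2nnc3sc(-c4ccc([N+](=O)[O-])cc4Cl)nn23)cc1` gives 69% in a functional assay on the whole organism (strain Wistar albino) for inhibition, with Rattus norvegicus as the target, read by paw edema, with stated times of 30 min and 3 h, at a dose of 20 mg/kg by the oral route (on this read-out lower numbers stand for less inhibition and higher numbers for more inhibition at the one dose given (going by the name of the read-out)), the highest of the three numbers, though not separated from its neighbour: compound 2 `CC(C)Cc1ccc(C(C)c2nnc3sc(-c4ccc(Br)cc4)nn23)cc1` gives 67%, a step of a number 2 percentage points higher from compound 2 to compound 3 (within the scatter), while compound 1 `CCc1nn2c(C(C)c3ccc(CC(C)C)cc3)nnc2s1` gives 55%, a step of a number 14 percentage points higher from compound 1 to compound 3 (beyond the scatter). Compound 4 `CC(C)Cc1ccc(C(C)c2nnc3sc(-c4ccco4)nn23)cc1` carries furan-2-yl in place of 2-chloro-4-nitrophenyl on an aromatic carbon. Going by the values given here, the steps that bear on this position are a number 12 percentage points higher from compound 1 to compound 2 (beyond the scatter) and a number 14 percentage points higher from compound 1 to compound 3 (beyond the scatter), both replacing ethyl with a six-membered aromatic ring of carbon only, and a number 2 percentage points higher from compound 2 to compound 3 (within the scatter), where one such ring replaced another. An aromatic ring at this position gave modestly more inhibition than ethyl, and the two rings tested did not differ beyond the scatter. Furan-2-yl is a five-membered aromatic ring with fewer heavy atoms, so a step of a number 7 percentage points lower from compound 3 to compound 4 (within the scatter) is expected. Compound 4 is estimated at 62%, with a range from 50% to 74%.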

Compound 4, a percentage reported as inhibition, in the whole organism at one dose (the size of the read-out at that dose, not a potency): 64%
Beside the measured number, compound 4's estimate is 2 percentage points below it; low and high end bracket the measured number.
By their numbers in this assay, from the lowest: compounds 1, 4, 2 and 3 (each within the scatter of the next, the first and the last beyond it).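

In this assay a five-membered aromatic ring with one hetero atom, furan-2-yl, stands level with the larger rings, with a number 5 percentage points lower from compound 3 to compound 4 (within the scatter) and a number 3 percentage points lower from compound 2 to compound 4 (within the scatter) as the two steps. It also stays within the scatter of ethyl, with a number 9 percentage points higher from compound 1 to compound 4 (within the scatter) as the step, so the clear gain over ethyl seen with both six-membered rings is not shown for every aromatic ring. Nothing measured here explains these numbers. Still open, going by these compounds, is how a longer chain than ethyl would compare, and whether an amine or a carboxylic acid on the ring would change the inhibition.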